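Swapping fluoro for hydroxy in compound 3

This account rests on a few compounds, and the source may have more. Where it says the series, first, only, none or still open, it means among the compounds named here.

Compound 1 `CN(C)C(=O)c1cc2cnc(Nc3ccc(NC(=O)C4(C(=O)Nc5ccc(F)cc5)CC4)cc3)nc2n1C1CCCC1` gives 65.4% growth inhibition
Compound 2 `CN(C)C(=O)c1cc2cnc(Nc3ccc(NC(=O)C4(C(=O)Nc5cccc(F)c5)CC4)cc3)nc2n1C1CCCC1` gives 26.3% growth inhibition

In a functional assay on OVCAR-5 cells (Homo sapiens) for inhibition, read by CCK-8 assay, with a stated time of 72 h, tested at 1 uM (a higher number here means more inhibition of growth at the concentration tested, a lower number less inhibition of growth), compound 2 is the lower of the two, with 26.3% as its reading. Compound 3 `CN(C)C(=O)c1cc2cnc(Nc3ccc(NC(=O)C4(C(=O)Nc5cccc(O)c5)CC4)cc3)nc2n1C1CCCC1` carries hydroxy in place of fluoro on an aromatic carbon and otherwise matches compound 2. Among the compounds with values here, only one measured step bears on this: a number 39.1 percentage points lower from compound 1 to compound 2 (beyond the scatter) is large and beyond the scatter. That step moved the fluoro rather than replacing it, so it warns that this ring can matter but gives no direction. In this assay no step beyond the scatter is therefore the likeliest outcome, though a wide range is kept. The estimated step is a number 5.7 percentage points higher from compound 2 to compound 3 (within the scatter) for this change. For compound 3 the expected value is 32% within an estimated range of 10% to 58% in this test.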

Compound 3, percent growth inhibition at one concentration: 58.5%
The estimate for compound 3 lay 26.5 percentage points below the measured number; measured number above the stated range.
By their numbers in this assay, from the lowest: compound 2; then compounds 3 and 1 (each within the scatter of the next).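

In this assay hydroxy in place of fluoro gives a number 32.2 percentage points higher from compound 2 to compound 3 (beyond the scatter) at this same ring carbon, so the weak reading of compound 2 does not hold for every group at this place. The comparison with the 4-fluorophenyl compound gives a number 6.9 percentage points lower from compound 1 to compound 3 (within the scatter) and shows no clear difference, so 3-hydroxyphenyl recovers what moving the fluoro lost. Nothing available explains why hydroxy and fluoro part ways here. As far as these compounds go, whether an amine or a methoxy group at this place would read like hydroxy remains open, as does how a 4-hydroxyphenyl group would compare with compound 1.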